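The source may report more compounds than this note shows. Statements on the series, on what has been measured and on what is new or still open speak of the compounds shown alone.

Compound 1 `O=C(CC1c2ccccc2N=C(SCCCCCN2CCCC2)N1c1ccc(-c2ccc(F)cc2)cc1)NCc1ccccc1` and compound 3 `O=C(CC1c2ccccc2N=C(SCCCCCN2CCCC2)N1c1ccc(-c2ccccc2)cc1)NCc1ccccc1` share a core and differ only where a fluoro on an aromatic carbon is exchanged for hydrogen. In an assay on cells for inhibition of Voltage-dependent T-type calcium channel subunit alpha-1G (Homo sapiens), read by patch clamp, tested at 10 uM (on this read-out lower numbers stand for less inhibition and higher numbers for more inhibition at the one concentration tested (going by the name of the read-out)), compound 1 gives 83.9%. Compound 3 gives 93.9% in this assay, so the change hydrogen in place of fluoro on an aromatic carbon makes a step of a number 10 percentage points higher from compound 1 to compound 3 (within the scatter).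

Compound 2 `CN(C)CCCCCSC1=Nc2ccccc2C(CC(=O)NCc2ccc(F)cc2)N1c1ccccc1` stands on a different core; how that core differs from the core of compound 1 is not broken down here. In this assay compound 2 gives 26.7%, the lowest of the three numbers, with compound 1 and compound 3 both beyond the scatter above it.

Compound 4 `CN(C)CCCCCSC1=Nc2ccccc2C(CC(=O)NCc2ccccc2)N1c1ccccc1` is the not yet measured partner of compound 2. The difference between the two is the change (hydrogen in place of fluoro on an aromatic carbon). The place of the change is the same as in the pair of compound 1 and compound 3, an aromatic carbon of a six-membered aromatic ring of carbon only, para to a large group; read one bond further out, it is (4-fluorobenzyl)amino to benzylamino here, where in compound 1 it was 4-fluorophenyl to phenyl.

Among the measured compounds shown here, the one step already seen for this change, a number 10 percentage points higher from compound 1 to compound 3 (within the scatter), lay within the scatter, and the expectation for compound 4 rests on that. The step expected from compound 2 to compound 4 is estimated at a number 5.3 percentage points higher from compound 2 to compound 4 (within the scatter). Compound 4 is therefore expected to give about 32% in this assay, estimated to lie between 15% and 50%.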

Compound 4, a percentage reported as inhibition, at one concentration (the size of the read-out at that concentration, not a potency): 46.5%
Compound 4: middle estimate off by 14.5 percentage points, on the low side, within the range that was stated.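

In this assay the exchange of fluoro for hydrogen gives a higher number on both cores, and the new step, a number 19.8 percentage points higher from compound 2 to compound 4 (beyond the scatter), passes beyond the scatter where the earlier one, a number 10 percentage points higher from compound 1 to compound 3 (within the scatter), stayed within it, yet the two steps cannot be told apart: the same change on two cores in this assay, a number 10 percentage points higher (within the scatter) from compound 1 to compound 3 and a number 19.8 percentage points higher (beyond the scatter) from compound 2 to compound 4, 9.8 percentage points apart, within the scatter of two such steps. Within these two pairs, then, the change carries from the core of compound 1 to the core of compound 2 without a measurable difference in its step, even though it sits on a 4-fluorophenyl group in the first pair and on a 4-fluorobenzyl group in the second. Among the compounds shown here, this does not show that the step has a fixed size or that it would hold on any further core, since it rests on only two pairs, each read at a single concentration.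

The compounds shown leave open how a chloro, methoxy or trifluoromethyl group on that same aromatic carbon would read against fluoro and hydrogen. They also leave open whether the step stays the same with a shorter chain to the amine, or with a piperidine or morpholine at the end of that chain.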